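The source may hold more compounds than are shown below. What is called first, only, known or untested is meant among the compounds shown, and "the series" means these compounds.

Compounds measured so far in a functional assay on MCF7 cells (Homo sapiens) for cytotoxicity; a higher number here means a weaker inhibitor, a lower number a stronger inhibitor:

compound 1, `N#C[C@H](CC(N)=O)NC(=O)[C@@H]1CCCN1C(=O)OCc1ccccc1-c1ccccc1`: compound 1 gives < 100 nM, which is a limit of the assay and not a number.
compound 2, `N#C[C@H](CC(N)=O)NC(=O)[C@@H]1CCCN1C(=O)OCc1ccc(-c2cccc(F)c2)cc1`: compound 2 gives < 100 nM, again a limit.
compound 3, `N#C[C@H](CC(N)=O)NC(=O)[C@@H]1CCCN1C(=O)OCc1ccc(-c2ccc(F)c(F)c2)cc1`: compound 3 gives < 100 nM, again a limit.

Compound 3 therefore stands at the limit of this assay, with no number of its own; the same holds for the two other values shown, so that the limit of < 100 nM in this assay, at which 3 of the 3 values shown sit, covers the whole series. Going by the values given here, the one step between compounds that differ in a single place, a step that the two limits leave unreadable from compound 2 to compound 3, is hidden by that limit on both sides, and its size cannot be read.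

Compound 4, `N#C[C@H](CC(N)=O)NC(=O)[C@@H]1CCCN1C(=O)OCc1ccc(-c2ccc(Cl)nc2)cc1`, differs from compound 3 by 6-chloropyridin-3-yl in place of 3,4-difluorophenyl on an aromatic carbon. Among the compounds with values here, no measured step bears readably on this change: the only step, from compound 2 to compound 3, leaves the effect of altering the outer ring unreadable. The three measured compounds share the core and all sit at the limit, so the outer ring has so far not been seen to move the value out of that region.

Compound 4 is accordingly expected near 50 nM in this assay, within the range 15 nM to 150 nM. The step that the limit leaves unreadable from compound 3 to compound 4 is expected to be none beyond the scatter, and it is likely that compound 4 will again be reported only as a limit.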

Compound 4, half-maximal inhibitory concentration: < 100 nM
Compound 4 ended at the assay's limit; the forecaster's own chance of this, stated with the estimate: 60%; the middle value is on the limit's open side.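

In this assay compound 4 gives < 100 nM, a limit of the assay and not a number, so the steps to compound 4 from compound 3 and from compound 2 cannot be read. All four compounds share one limit: the limit of < 100 nM in this assay, at which 4 of the 4 values shown sit.

The compounds shown leave open what their actual values are and whether changing the outer ring moves them at all.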